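The compounds below may be only part of what the source reports. "The series", "measured", "known", "first", "only" and "open" are said of these compounds alone.

Compound 1 `O=C(/C(=C\c1ccc(Br)cc1)Sc1ccc(Br)cc1)c1ccc(Br)cc1`: 1000 nM
Compound 2 `O=C(/C(=C\c1ccc(Br)cc1)Sc1ccccc1Br)c1ccc(Br)cc1`: 1000 nM
Compound 3 `O=C(/C(=C\c1ccc(Br)cc1)SCc1ccc(F)cc1)c1ccc(Br)cc1`: 25000 nM

These numbers come from a functional assay on DU-145 cells (Homo sapiens) for inhibition, read by trypan blue exclusion, with a stated time of 96 h; on this read-out higher numbers stand for weaker inhibition of growth and lower numbers for stronger inhibition of growth. Compound 2 stands level with compound 1, together the lowest of the three numbers, while compound 3 lies well higher.

The next compound is compound 4 `O=C(/C(=C\c1c(O)cc(O)cc1O)Sc1ccccc1Br)c1ccc(Br)cc1`. In it, 2,4,6-trihydroxyphenyl takes the place of 4-bromophenyl on a double-bonded chain carbon bound to a double-bonded chain carbon (2,4,6-trihydroxyphenyl in place of 4-bromophenyl on a double-bonded chain carbon bound to a double-bonded chain carbon).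

Among the compounds with values here, no measured step touches that carbon. All three changes are on the sulfur, so they bear on this one only indirectly. There, no change at the digits printed from compound 1 to compound 2 (within the scatter), yet a 25-fold higher number from compound 2 to compound 3 (1.40 log units; beyond the scatter), and a 25-fold higher number from compound 1 to compound 3 (1.40 log units; beyond the scatter). These steps show that one swap on this core can shift the number far, so a step beyond the scatter is expected here too. Its direction is a judgement, since the data hold no test of it, and a higher number seems more likely. The expected step is a 4.0-fold higher number from compound 2 to compound 4 (0.60 log units; beyond the scatter).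

The estimate for compound 4 is 4000 nM, with an expected range from 500 nM to 25000 nM.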

Compound 4, concentration for 50% growth inhibition: > 100000 nM
Compound 4 was reported as a limit; the forecaster's own chance of this, stated with the estimate: 5%; middle value at least 25-fold (1.39 log units) away from the limit.
By their numbers in this assay, from the lowest: compounds 1 and 2 (each within the scatter of the next); then compound 3. At a limit, above all of these: compound 4.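

Within the data shown here, every earlier change sat on the sulfur, so this is the first look at the double-bonded chain carbon, and it shows that this position matters as well. In this assay, 2,4,6-trihydroxyphenyl in place of 4-bromophenyl gives an at least 100-fold higher number from compound 2 to compound 4 (2.00 log units; beyond the scatter), a loss of growth inhibition that goes further than the change on the sulfur that gave a 25-fold higher number from compound 2 to compound 3 (1.40 log units; beyond the scatter). For compound 4 the reading is a limit and not a number: the limit of > 100000 nM in this assay, at which 1 of the 4 values shown sits.

The compounds shown leave open which part of this swap counts, the loss of the bromine or the arrival of the hydroxyl groups. A plain phenyl ring or a methoxyphenyl group on this carbon would help to pull those two apart.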